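The compounds below may be only part of what the source reports. "The series", "measured", "known", "first", "only" and "open" are said of these compounds alone.

Of the compounds shown here, three have been measured in an assay on isolated protein for inhibition of Deoxyuridine 5'-triphosphate nucleotidohydrolase, mitochondrial (Homo sapiens); on this read-out higher numbers stand for weaker inhibition and lower numbers for stronger inhibition. Compound 1 `O=c1ccn(CCCCO[Si](c2ccccc2)(c2ccccc2)c2ccccc2)c(=O)[nH]1` reaches only a limit of the assay, > 1000000 nM. Compound 2 `O=C(OCCCCn1ccc(=O)[nH]c1=O)c1ccccc1` gives 496000 nM. Compound 3 `O=c1ccn(CC(CO)CCOC(c2ccccc2)(c2ccccc2)c2ccccc2)c(=O)[nH]1` gives 260000 nM, the lowest of the two numbers, though the gap to compound 2 lies within the usual scatter and carries no order. Compound 4 `[N-]=[N+]=NCC(CCOC(c1ccccc1)(c1ccccc1)c1ccccc1)Cn1ccc(=O)[nH]c1=O` differs from compound 3 in one place: azido in place of hydroxy on a saturated chain carbon, three bonds along the chain from an aromatic nitrogen. Going by the values given here, no measured pair shows this exchange, so the data give no direction for it. The expected step from compound 3 to compound 4 is a 1.2-fold higher number from compound 3 to compound 4 (0.06 log units; within the scatter), no larger than the scatter. Compound 4 is therefore estimated at 300000 nM, within 100000 nM to 1000000 nM.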

Compound 4, inhibition constant: > 1000000 nM
Compound 4: no number, only a limit; the forecaster's own chance of this, stated with the estimate: 25%; middle value at least 3.3-fold (0.52 log units) from the limit.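

Replacing hydroxy with azido at this position on the chain does not leave inhibition unchanged in this assay: the exchange gives an at least 3.8-fold higher number from compound 3 to compound 4 (0.58 log units; beyond the scatter). It is the only step among the compounds shown, and it gives this position a direction that the earlier compounds could not. As far as these compounds go, its full size stays unknown, since compound 4 stands at a limit of the assay and not at a number: the limit of > 1000000 nM in this assay, at which 2 of the 4 values shown sit.

From the compounds shown here alone, whether an amine or a carboxylic acid at this carbon would keep the inhibition of compound 3 remains open. So does whether a longer chain carrying the hydroxy would do the same.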